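Carbamoyl in Place of Cyano on the Aryl Nitrogen Chain

This account rests on a few compounds, and the source may have more. Where it says the series, first, only, none or still open, it means among the compounds named here.

Of the compounds shown here, three sharing one core have been measured in an assay on isolated protein for inhibition of Thymidylate synthase (Mus musculus); on this read-out higher numbers stand for weaker inhibition and lower numbers for stronger inhibition. Compound 1 `CCN(Cc1ccc2nc(C)[nH]c(=O)c2c1)c1ccc(C(=O)N[C@@H](CCC(=O)O)C(=O)O)c(F)c1` gives 45 nM. Compound 2 `Cc1nc2ccc(CN(CC#N)c3ccc(C(=O)N[C@@H](CCC(=O)O)C(=O)O)c(F)c3)cc2c(=O)[nH]1` gives 170 nM, and compound 3 `CCN(Cc1ccc2nc(C)[nH]c(=O)c2c1)c1ccc(C(=O)N[C@@H](CCC(=O)O)C(=O)O)c(Cl)c1` gives 120 nM. Compound 2 thus stands at the highest number of the three: its value and that of compound 3 lie within the scatter of each other, while the step of a 3.8-fold higher number from compound 1 to compound 2 (0.58 log units; beyond the scatter) lies beyond it. The other step shown, a 2.7-fold higher number from compound 1 to compound 3 (0.43 log units; beyond the scatter), concerns the aromatic halogen and not the chain on the aryl nitrogen.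

The step of interest leads from compound 2 to compound 4 `Cc1nc2ccc(CN(CC(N)=O)c3ccc(C(=O)N[C@@H](CCC(=O)O)C(=O)O)c(F)c3)cc2c(=O)[nH]1`, the change being (carbamoyl in place of cyano on a saturated chain carbon bound to a nitrogen on an aromatic ring). Within the data shown here, only one measured step bears on this position, the exchange from compound 1 to compound 2, which weakened inhibition modestly. Among the measured compounds shown here, for a carbamoyl in place of a cyano no measured step is available, so the expectation rests on the observation that the cyano analogue already sits at the weaker end. Compound 4 is therefore expected to remain near compound 2, with a step of a 1.3-fold higher number from compound 2 to compound 4 (0.11 log units; within the scatter) that may not exceed the scatter, and its value in this assay is estimated at 220 nM, within a range from 90 nM to 550 nM.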

Compound 4, half-maximal inhibitory concentration: 1340 nM
Compound 4: middle estimate off by 6.1-fold (0.78 log units), on the low side; measured number above the stated range.
By their numbers in this assay, from the lowest: compound 1; then compounds 3 and 2 (each within the scatter of the next); then compound 4.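

In this assay, carbamoyl in place of cyano on a saturated chain carbon bound to a nitrogen on an aromatic ring gives a 7.9-fold higher number from compound 2 to compound 4 (0.90 log units; beyond the scatter) and so shows that the cyano analogue did not mark the weak end of this position. Set against the methyl of compound 1, the same place now carries a 30-fold higher number from compound 1 to compound 4 (1.47 log units; beyond the scatter) as a large step, whereas the only earlier step here, a 3.8-fold higher number from compound 1 to compound 2 (0.58 log units; beyond the scatter), was modest, so the three earlier compounds had shown only part of how far inhibition moves with this chain. The counted difference between cyanomethyl and carbamoylmethyl is small, one more heavy atom and one hydrogen-bond donor, but nothing at hand accounts for the size of the step.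

How a carboxylic acid, a primary amine or a longer chain would read on this same chain carbon remains open, so the compounds shown do not tell whether the carbamoyl stands alone or belongs to a wider trend. Also open, from the compounds shown here alone, is whether chloro in place of fluoro on an aromatic carbon would shift the carbamoylmethyl compound as it shifted compound 1.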